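The compounds below may be only part of what the source reports. "The series", "measured", "known", "first", "only" and "open" are said of these compounds alone.

Working notes on the series. All three measured compounds share one core and differ only in the aryl group on a double-bonded chain carbon bound to a double-bonded ring carbon. In a functional assay on JAR cells (Homo sapiens) for inhibition, read by MTT assay, with a stated time of 72 h, tested at 10 uM (a lower number here means less inhibition, a higher number more inhibition at the concentration tested (going by the name of the read-out)), compound 1 `CCOC(=O)C1=C(Nc2ccccc2)S/C(=C\c2ccc(O)c(O)c2)C1=O` gives 48.7%. Compound 2 `CCOC(=O)C1=C(Nc2ccccc2)S/C(=C\c2cccc(C(=O)O)c2)C1=O` gives 50.6% in this assay; the step of a number 1.9 percentage points higher from compound 1 to compound 2 (within the scatter) lies within the scatter, so no order between these two is claimed. Compound 3 `CCOC(=O)C1=C(Nc2ccccc2)S/C(=C\c2cc3ccncc3[nH]2)C1=O` gives 26.3% in this assay and stands lowest of the three numbers, with both steps into it, a number 22.4 percentage points lower from compound 1 to compound 3 (beyond the scatter) and a number 24.3 percentage points lower from compound 2 to compound 3 (beyond the scatter), beyond the scatter and of modest size.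

Compound 4 `CCOC(=O)C1=C(Nc2ccccc2)S/C(=C\c2cc3cnccc3[nH]2)C1=O` is not yet measured. The change from compound 3 is a group of 9 heavy atoms (7 carbon, 2 nitrogen; one five-membered aromatic ring with 1 hetero atom, one six-membered aromatic ring with 1 hetero atom) in place of a group of 9 heavy atoms (7 carbon, 2 nitrogen; one five-membered aromatic ring with 1 hetero atom, one six-membered aromatic ring with 1 hetero atom), on a double-bonded chain carbon bound to a double-bonded ring carbon; the two structures hold the same atoms, joined differently. Among the measured compounds shown here, no measured step bears directly on this change: the two steps that reach compound 3 replace a six-membered ring of carbon only by the bicyclic group, and no measured pair exchanges one such bicyclic group for another. With the same atom count, donor count and acceptor count on both sides, a step in this assay of no more than the scatter is expected, in no fixed direction. The estimate for compound 4 in this assay is 30%, expected to fall between 15% and 48%, which means an expected step of a number 3.7 percentage points higher from compound 3 to compound 4 (within the scatter).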

Compound 4, a percentage reported as inhibition, at one concentration (the size of the read-out at that concentration, not a potency): < 10%
Compound 4 was reported as a limit; the forecaster's own chance of this, stated with the estimate: 0%; at least 20 percentage points between middle value and limit.
By their numbers in this assay, from the lowest: compound 3; then compounds 1 and 2 (each within the scatter of the next). At a limit, below all of these: compound 4.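

Compound 4 is reported only as a limit in this assay, not as a number: the limit of < 10% in this assay, at which 1 of the 4 values shown sits.

Even so, the step can be read, a number at least 16.3 percentage points lower from compound 3 to compound 4 (beyond the scatter), so on a double-bonded chain carbon bound to a double-bonded ring carbon, the same atoms joined differently, with the same donor and acceptor counts, change the read-out beyond the scatter. The steps that reach compound 3 could not show this, as each replaces a six-membered ring of carbon only by a bicyclic group. Against those carbon-only aryl groups the steps are large, a number at least 40.6 percentage points lower from compound 2 to compound 4 (beyond the scatter) and a number at least 38.7 percentage points lower from compound 1 to compound 4 (beyond the scatter), while both steps into compound 3 are modest, so in this small set the two bicyclic groups do not behave as one interchangeable group.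

Open, as far as these compounds go, is whether other arrangements of the nitrogen in the six-membered ring of the bicyclic group would give numbers like those of compound 3 or fall to a limit like compound 4. Also open, from the compounds shown here alone, is whether an amine or a carboxylic acid carried on the bicyclic group would restore the read-out seen with the carbon-only aryl groups.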